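A few compounds are considered here, and "the series" means these few. Any claim that something is new, unique, unknown or untested is made for them only; others in the source may bear on it.

Measured compounds in an ADME assay on HEK-293T cells (Homo sapiens) for cytotoxicity, read by MTT assay, with a stated time of 48 h, in the absence of a further agent; on this read-out lower numbers stand for stronger inhibition and higher numbers for weaker inhibition:
compound 1 `O=C(Nc1ccccc1)c1csc(-c2cn(Cc3ccc(Cl)cc3)c3ccccc23)n1`: > 100000 nM, a limit of the assay and not a number
compound 2 `COc1ccc2[nH]cc(-c3nc(C(=O)Nc4cc(OC)c(OC)c(OC)c4)cs3)c2c1`: 8600 nM
compound 3 `O=C(Nc1ccccc1)c1csc(-c2c[nH]c3ccccc23)n1`: 41100 nM

Compound 2 holds the lowest of the two numbers; compound 3 is its nearest neighbour and sits higher, beyond the scatter. Among the compounds with values here, the only measured step is an at least 2.4-fold lower number from compound 1 to compound 3 (0.38 log units; beyond the scatter), hydrogen in place of 4-chlorobenzyl on an aromatic nitrogen; it starts from the limit of > 100000 nM in this assay, at which 1 of the 3 values shown sits, and so only sets a floor on its size. Compound 4 `COc1cc(NC(=O)c2csc(-c3c[nH]c4ccc(Br)cc34)n2)cc(OC)c1OC` differs from compound 2 by bromo in place of methoxy on an aromatic carbon. Within the data shown here, that step touches the six-membered carbon ring of the fused system, a place on which no measured step gives any information; the nitrogen step does not bear on it. With nothing to point either way, the expectation for this assay is a step within the scatter, a 1.2-fold higher number from compound 2 to compound 4 (0.07 log units; within the scatter). Compound 4 is therefore estimated at 10000 nM, in the range 3000 nM to 40000 nM, with the range kept wide.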

Compound 4, half-maximal inhibitory concentration: > 100000 nM
Compound 4: a limit, no number; the forecaster's own chance of this, stated with the estimate: 5%; at least 10-fold (1.00 log units) between middle value and limit.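

In this assay, the six-membered aromatic ring of carbon only, part of the fused system, now proves responsive to change: bromo in place of methoxy on an aromatic carbon gives an at least 11-fold higher number from compound 2 to compound 4 (1.06 log units; beyond the scatter). Compound 4 gives > 100000 nM, which is a limit of the assay and not a number. The step therefore fixes only a floor on its size, and the true gap cannot be read from this pair: the limit of > 100000 nM in this assay, at which 2 of the 4 values shown sit.

Only methoxy and bromo are shown on this carbon, so the compounds do not separate the loss of methoxy from the entry of bromo. As far as these compounds go, how a hydroxyl, a fluoro or an amine at this place would read remains open.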